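The source may hold more compounds than are shown below. What is called first, only, known or untested is meant among the compounds shown, and "the series" means these compounds.

Measured so far in an assay on HEK293 cells for positive allosteric modulation of metabotropic glutamate receptor 3 (Rattus norvegicus), read by thallium flux, with a stated time of 2.5 min; a lower number here means a smaller maximal response, a higher number a larger maximal response:

Compound 1 `Cc1c(OCCCCOc2ccc(C(=O)O)cc2)ccc(C(=O)CC2CCCC2)c1O` gives 26.7%.
Compound 2 `Cc1c(OCCCCOCOc2ccc(C(=O)O)cc2)ccc(C(=O)CC2CCCC2)c1O` gives 46.9%.
Compound 3 `COc1ccc(C(=O)O)cc1OCCCCOc1ccc(C(=O)CC2CCCC2)c(O)c1C` gives 67.6%.

Compound 1 stands lowest of these three. The nearer step up is a number 20.2 percentage points higher from compound 1 to compound 2 (beyond the scatter), and the further one is a number 40.9 percentage points higher from compound 1 to compound 3 (beyond the scatter). Both of these steps, and also a number 20.7 percentage points higher from compound 2 to compound 3 (beyond the scatter), change the group that hangs on an oxygen on a saturated carbon, at the acid-bearing end of the molecule.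

Compound 4 `Cc1c(OCCCCOc2ccc(C(=O)O)cc2)ccc(C(=O)CC(C)C)c1O` has not yet been measured. It differs from compound 1 at the other end: isopropyl in place of cyclopentyl on a saturated chain carbon bound to a carbonyl carbon. The cyclopentyl leaves and an isopropyl enters, on a saturated chain carbon bound to a carbonyl carbon.

For the measured compounds named here, none of the measured steps touches this carbonyl side, so no measured step bears directly on the change from compound 1 to compound 4. The measured steps only show that the largest response can shift considerably when one end of the molecule is altered. Without a comparable step at the carbonyl end, the expectation for compound 4 is a step of a number 1.3 percentage points higher from compound 1 to compound 4 (within the scatter), that is, no shift beyond the scatter, but with a wide range. Compound 4 is therefore estimated at 28%, expected to fall between 12% and 50%.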

Compound 4, largest response reached (reported as percent of maximum), in percent of the reference or control that the assay uses: 51.9%
Beside the measured number, compound 4's estimate is 23.9 percentage points below it; measured number above the stated range.
By their numbers in this assay, from the lowest: compound 1; then compounds 2 and 4 (each within the scatter of the next); then compound 3.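

In this assay, the carbonyl end of the molecule proves able to change the largest response, as there is a number 25.2 percentage points higher from compound 1 to compound 4 (beyond the scatter) with isopropyl in place of cyclopentyl on a saturated chain carbon bound to a carbonyl carbon. For the compounds shown here, all the earlier steps changed only the acid-bearing end, so this is the first measured sign that this second end matters too, and here the change that raises the number removes the ring and goes from five heavy atoms to three. Nothing available explains why this exchange raises the response.

One pair of compounds cannot separate the loss of the ring from the loss of carbon atoms, and a cyclobutyl group, a straight propyl chain or a tert-butyl group at the same place would help to tell these apart. As far as these compounds go, it also remains open whether the isopropyl exchange would raise the response in the same way on a molecule carrying 5-carboxy-2-methoxyphenyl or (4-carboxyphenoxy)methyl at the acid-bearing end, or whether the changes at the two ends would not add up.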